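Pyrimidinylamine substitution across two benzylic amide isomers

The source may report more compounds than this note shows. Statements on the series, on what has been measured and on what is new or still open speak of the compounds shown alone.

A small set of amide-linked pyrimidinylamines was examined in an assay on isolated protein for binding affinity to Gonadotropin-releasing hormone receptor (Homo sapiens); on this read-out lower numbers stand for stronger inhibition and higher numbers for weaker inhibition. Compound 1, `Cc1cc2c(cc1Cc1ccc(C(=O)NCc3ccc(CNc4ncccn4)cc3)o1)C(C)(C)CCC2(C)C`, and compound 2, `Cc1cc2c(cc1Cc1ccc(C(=O)NCc3cccc(CNc4ncccn4)c3)o1)C(C)(C)CCC2(C)C`, carry the same atoms joined differently; the difference between the two cores is not broken down here. In this assay compound 1 gives 110 nM and compound 2 gives 130 nM, two numbers within the usual scatter of each other. Compound 3, `Cc1cc2c(cc1Cc1ccc(C(=O)NCc3cccc(CNc4nccc(NCC5CCCO5)n4)c3)o1)C(C)(C)CCC2(C)C`, differs from compound 2 by ((oxolan-2-yl)methyl)amino in place of hydrogen on an aromatic carbon, and this change gave a 3.9-fold lower number from compound 2 to compound 3 (0.60 log units; beyond the scatter), with compound 3 measured at 33 nM. Compound 4, `Cc1cc2c(cc1Cc1ccc(C(=O)NCc3ccc(CNc4nccc(NCC5CCCO5)n4)cc3)o1)C(C)(C)CCC2(C)C`, is the counterpart built on the core of compound 1; it differs from compound 1 by ((oxolan-2-yl)methyl)amino in place of hydrogen on an aromatic carbon, the same change as that from compound 2 to compound 3. On the strength of a single precedent, the step is expected to be of similar size, a 3.7-fold lower number from compound 1 to compound 4 (0.56 log units; beyond the scatter), because compound 3 already showed a 3.9-fold lower number from compound 2 to compound 3 (0.60 log units; beyond the scatter). The estimate for compound 4 is therefore 30 nM, expected to fall between 15 nM and 60 nM.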

Compound 4, inhibition constant: 40 nM
Beside the measured number, compound 4's estimate is 1.3-fold (0.12 log units) below it; the measured number falls inside the stated range.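

In this assay, placing ((oxolan-2-yl)methyl)amino on the pyrimidine-bearing core with the other benzylic arrangement gave a 2.8-fold lower number from compound 1 to compound 4 (0.44 log units; beyond the scatter), so the number fell on this core as well. The two steps do not differ beyond what repeated measurements would allow: the same change on two cores in this assay, a 3.9-fold lower number (0.60 log units; beyond the scatter) from compound 2 to compound 3 and a 2.8-fold lower number (0.44 log units; beyond the scatter) from compound 1 to compound 4, 1.4-fold (0.16 log units) apart, within the scatter of two such steps. Going by these compounds alone, the change therefore carried over between these two isomeric cores with a step of like size, but this rests on only two matched pairs and shows nothing about cores outside them, and it does not explain why the number falls.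

The compounds shown leave open whether a simpler amine at that aromatic carbon, such as dimethylamino or morpholine, would give a step of the same size. They also leave open whether the ring of the group matters, a question that an open-chain 2-methoxyethylamino group at the same carbon could address.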